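Series notes: dropping one methoxy from compound 2

The source may hold more compounds than are shown below. What is called first, only, known or untested is meant among the compounds shown, and "the series" means these compounds.

Among the measured compounds shown here, compound 2 `COc1ccc(C(=O)/C=C/c2cc(-c3cc(OC)c(OC)c(OC)c3)n[nH]2)cc1OC` gives 99% in a functional assay on CAKI-1 cells (Homo sapiens) for cytotoxicity, read by sulforhodamine B assay, with a stated time of 48 h, tested at 0.1 uM (a higher number here means a weaker effect of the compound at the concentration tested, a lower number a stronger effect), the higher of the two numbers so far; compound 1 `COc1cc(-c2cc(/C=C/C(=O)c3ccc(Cl)c(Cl)c3)[nH]n2)cc(OC)c1OC` gives 91%. For the measured compounds named here, the only measured step, a number 8 percentage points higher from compound 1 to compound 2 (within the scatter), replaces one ring substituent pattern with another and bears only loosely on the change at hand. Compound 3 `COc1ccc(C(=O)/C=C/c2cc(-c3cc(OC)c(OC)c(OC)c3)n[nH]2)cc1` differs from compound 2 by hydrogen in place of methoxy on an aromatic carbon. Both measured numbers sit high, and no step beyond the scatter has appeared, so compound 3 is expected to sit in the same region, with an estimated step of a number 3 percentage points lower from compound 2 to compound 3 (within the scatter). Compound 3 is therefore estimated at 96%, in a range from 84% to 105%.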

Compound 3, a percentage reported as activity, at one concentration (the size of the read-out at that concentration, not a potency): 93%
Compound 3: the middle estimate sits 3 percentage points above what was measured; the range from low to high includes it.
By their numbers in this assay, from the lowest: compounds 1, 3 and 2 (each within the scatter of the next).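

In this assay, among the compounds shown here, the step of a number 6 percentage points lower from compound 2 to compound 3 (within the scatter) gives the first direct reading of this change: going from 3,4-dimethoxyphenyl to 4-methoxyphenyl does not move the read-out past the scatter. The step of a number 2 percentage points higher from compound 1 to compound 3 (within the scatter) likewise separates the 4-methoxyphenyl from the 3,4-dichlorophenyl by no more than the scatter, so all three patterns on the carbonyl carbon read alike at this one concentration. Nothing available bears on a cause for this.

As far as these compounds go, whether an amine, a hydroxyl or a longer chain at this position would shift the number remains open. So does whether these groups would separate at a concentration where the compounds show a stronger effect.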